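Configuration step from compound 2 to compound 3

The source may report more compounds than this note shows. Statements on the series, on what has been measured and on what is new or still open speak of the compounds shown alone.

In a functional assay on a cell-free system (plasma, Rattus norvegicus) (a lower number here means a stronger inhibitor, a higher number a weaker inhibitor), compound 1 `O=C(NCc1cc(Cl)ccc1-n1cnnn1)[C@@H]1CC=NN1C(=O)[C@H](O)c1ccccc1` gives 1100 nM. Compound 2 `O=C(NCc1cc(Cl)ccc1-n1cnnn1)[C@@H]1C[C@H]2C[C@H]2N1C(=O)[C@H](O)c1ccccc1` gives 820 nM, which lies within the scatter of the value for compound 1. Compound 3 `O=C(NCc1cc(Cl)ccc1-n1cnnn1)[C@@H]1C[C@@H]2C[C@@H]2N1C(=O)[C@H](O)c1ccccc1` is related to compound 2 as follows: the two compounds have the same atoms and bonds and differ only in configuration as drawn: 2 of 4 stereo elements differ; a stereocentre at a saturated ring carbon is drawn R in compound 2 and S in compound 3; a stereocentre at a saturated ring carbon is drawn R in compound 2 and S in compound 3. Among the measured compounds shown here, no measured pair shows a step of this kind, so the expectation is a judgement. A moderate move to a higher number in this assay is expected, slightly beyond the scatter. The estimated change is a 2.4-fold higher number from compound 2 to compound 3 (0.39 log units; beyond the scatter). For compound 3 the expected value is 2000 nM, with an estimated range of 500 nM to 8000 nM.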

Compound 3, half-maximal inhibitory concentration in the Rattus norvegicus assay: 690 nM
The estimate for compound 3 lay 2.9-fold (0.46 log units) above the measured number; the measured number falls inside the stated range.
By their numbers in the Rattus norvegicus assay, from the lowest: compounds 3, 2 and 1 (each within the scatter of the next).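

Among the compounds shown here, in the Rattus norvegicus assay, compound 2 gives 820 nM and compound 3 gives 690 nM; the change of configuration at the two saturated ring carbons gives a 1.2-fold lower number from compound 2 to compound 3 (0.07 log units; within the scatter), so this is the first evidence that these two drawn configurations are not separated at this position. In a physicochemical assay for solubility, measured as kinetic solubility, at pH 6.8 (on this read-out lower numbers stand for lower solubility and higher numbers for higher solubility), compound 2 gives 100000 nM and compound 3 gives 97000 nM; the same change gives a 1.0-fold lower number from compound 2 to compound 3 (0.01 log units; within the scatter), again without separating them. The comparison isolates configuration at these carbons: the fact that compounds 2 and 3 differ only in the configuration as drawn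

Still open, going by these compounds, is whether configuration at these carbons remains without measurable consequence once an amine or a carboxylic acid is carried on the shared core. The other stereocentres of the series also remain untested by any step shown.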